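Trifluoromethoxy in place of trifluoromethyl at the far ring

The source may report more compounds than this note shows. Statements on the series, on what has been measured and on what is new or still open speak of the compounds shown alone.

In a functional assay on COLO 205 cells (Homo sapiens) for inhibition, read by sulforhodamine B assay (a lower number here means a stronger inhibitor of growth, a higher number a weaker inhibitor of growth), compound 2 (`Cc1ccc2[nH]c(-c3ccc(-c4ccc(-c5ccc(F)cc5)cc4)cc3)nc2c1`) gives 100000 nM, compound 3 (`Cc1ccc2[nH]c(-c3ccc(-c4ccc(-c5ccc(C(F)(F)F)cc5)cc4)cc3)nc2c1`) gives 30600 nM and compound 1 (`Oc1cccc2[nH]c(-c3ccc(-c4ccc(-c5ccc(OC(F)(F)F)cc5)cc4)cc3)nc12`) gives 8320 nM. Compound 3 therefore stands in the middle of the three numbers. Compound 4 (`Cc1ccc2[nH]c(-c3ccc(-c4ccc(-c5ccc(OC(F)(F)F)cc5)cc4)cc3)nc2c1`) has trifluoromethoxy in place of trifluoromethyl on an aromatic carbon, para to a large group: trifluoromethoxy in place of trifluoromethyl on an aromatic carbon.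

Among the measured compounds shown here, one measured step bears on this place: a 3.3-fold lower number from compound 2 to compound 3 (0.51 log units; beyond the scatter), a modest change with trifluoromethyl in place of fluoro. Compound 1 already carries trifluoromethoxy, and its number is lower than that of compound 3, but the two also differ in the core, so this gap cannot be assigned to the group alone. For the measured compounds named here, no measured step isolates the trifluoromethoxy group. A small move towards a lower number is therefore expected, no larger than the modest step seen and possibly within the scatter. The expected step is a 1.5-fold lower number from compound 3 to compound 4 (0.18 log units; within the scatter). The estimated value for compound 4 is 20000 nM, with an expected range from 8000 nM to 50000 nM.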

Compound 4, concentration for 50% growth inhibition: 30600 nM
Estimate against measurement, compound 4: 1.5-fold (0.18 log units) below, within the range that was stated.
By their numbers in this assay, from the lowest: compound 1; then compounds 3 and 4 (each within the scatter of the next); then compound 2.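

In this assay, the change at the far ring leaves no mark: no change at the digits printed from compound 3 to compound 4 (within the scatter), so trifluoromethoxy and trifluoromethyl cannot be told apart at this position. Trifluoromethoxy also stands where trifluoromethyl stood relative to fluoro, with a 3.3-fold lower number from compound 2 to compound 4 (0.51 log units; beyond the scatter). Among the compounds shown here, with trifluoromethoxy held fixed, a 3.7-fold higher number from compound 1 to compound 4 (0.57 log units; beyond the scatter), which isolates a difference in the core that the earlier compounds could not separate from the far-ring group.

On these data alone, it remains open whether an amine or a carboxylic acid at the far ring would move the number, and whether the core of compound 1 would keep its lower number with trifluoromethyl or fluoro in place of trifluoromethoxy. Nothing given here accounts for any of these steps.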